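Swapping the Bromophenyl Arm of Compound 1 for a Fused Ring

The source may report more compounds than this note shows. Statements on the series, on what has been measured and on what is new or still open speak of the compounds shown alone.

Measured so far:
- compound 1 `O=C(NNc1ccnc2cc(Cl)ccc12)c1ccccc1/N=C/c1ccc(Br)cc1`: 5.76
- compound 2 `COc1ccc(/C=N/c2ccccc2C(=O)NNc2ccnc3cc(Cl)ccc23)cc1OC`: 4.97
- compound 3 `O=C(NNc1ccnc2cc(Cl)ccc12)c1ccccc1/N=C/c1ccc([N+](=O)[O-])cc1`: 4.58

In a physicochemical assay for lipophilicity, measured as octanol-water partition (on this read-out higher numbers stand for higher lipophilicity and lower numbers for lower lipophilicity), compound 1 gives 5.76, the highest of the three numbers. Compound 2 sits nearer, with a number 0.79 log units lower from compound 1 to compound 2 (beyond the scatter), and compound 3 furthest, with a number 1.18 log units lower from compound 1 to compound 3 (beyond the scatter). Between these two, a number 0.39 log units lower from compound 2 to compound 3 (beyond the scatter).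

Compound 4 `O=C(NNc1ccnc2cc(Cl)ccc12)c1ccccc1/N=C/c1cc2ccccc2[nH]c1=O` has not yet been measured in this assay. It differs from compound 1 in one place: a group of 11 heavy atoms (9 carbon, 1 nitrogen, 1 oxygen; one six-membered aromatic ring of carbon only, one six-membered aromatic ring with 1 hetero atom) in place of a group of 7 heavy atoms (6 carbon, 1 bromine; one six-membered aromatic ring of carbon only), on a carbon with a double bond to nitrogen. Among the compounds with values here, none of the measured steps makes exactly this change, but both steps away from compound 1 replace the 4-bromophenyl group and both lower the number, one modestly and one by a large amount. The entering group here is larger still and brings a hydrogen-bond donor and a hydrogen-bond acceptor, so a step downward beyond the scatter is expected, of about a number 1.36 log units lower from compound 1 to compound 4 (beyond the scatter). Compound 4 is therefore estimated at 4.4, within a range from 3.7 to 5.1.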

Compound 4, partition coefficient: 4.65
Estimate against measurement, compound 4: 0.25 log units below; measured number inside the range.
By their numbers in this assay, from the lowest: compounds 3 and 4 (each within the scatter of the next); then compound 2; then compound 1.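

In this assay, a fused two-ring group at this position, on the carbon with a double bond to nitrogen, also falls short of the 4-bromophenyl group, with a number 1.11 log units lower from compound 1 to compound 4 (beyond the scatter), so compound 1 stays the highest of the four. Against the 3,4-dimethoxyphenyl group the new group shows a number 0.32 log units lower from compound 2 to compound 4 (beyond the scatter), while the comparison with the 4-nitrophenyl group gives a number 0.07 log units higher from compound 3 to compound 4 (within the scatter), so this read-out does not separate these two quite different groups. Nothing measured here explains why the groups fall where they do.

The compounds shown leave open where a plain phenyl, a 4-aminophenyl or a 4-carboxyphenyl group would fall at this position. They also leave open whether a longer carbon chain in place of the ring would keep the number close to that of compound 1.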